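This account rests on a few compounds, and the source may have more. Where it says the series, first, only, none or still open, it means among the compounds named here.

Measured compounds:
compound 1, `C[C@@H](O[C@H]1CN2C(=O)C=C(c3ccc(CO)cc3)CC2[C@@H]1c1ccc(F)cc1)c1cc(C(F)(F)F)cc(C(F)(F)F)c1`, 0.39 nM in an assay on CHO cells for displacement of a labelled ligand from Substance-P receptor (Homo sapiens); a higher number here means a weaker inhibitor, a lower number a stronger inhibitor
compound 2, `C[C@@H](O[C@H]1CN2C(=O)C=C(c3ccncc3)CC2[C@@H]1c1ccc(F)cc1)c1cc(C(F)(F)F)cc(C(F)(F)F)c1`, 0.14 nM in this assay

Compound 2 holds the lowest of the two numbers recorded in this assay. Within the data shown here, its only neighbour is compound 1, and the single measured step, a 2.8-fold lower number from compound 1 to compound 2 (0.44 log units; beyond the scatter), separates the two; that step exchanged one aromatic ring for another on the double-bonded ring carbon of the shared core and was modest in size.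

Compound 3, `C[C@@H](O[C@H]1CN2C(=O)C=C(c3cc[n+]([O-])cc3)CC2[C@@H]1c1ccc(F)cc1)c1cc(C(F)(F)F)cc(C(F)(F)F)c1`, has not been measured. It differs from compound 2 by a group of 7 heavy atoms (5 carbon, 1 nitrogen, 1 oxygen; one six-membered aromatic ring with 1 hetero atom) in place of a group of 6 heavy atoms (5 carbon, 1 nitrogen; one six-membered aromatic ring with 1 hetero atom), on a double-bonded ring carbon. The ring itself is kept; one oxygen atom is added to the ring nitrogen, and the group that enters has no common name. Among the measured compounds shown here, no measured step covers this kind of change. For the measured compounds named here, the one step that bears on it at all is the earlier ring exchange, and it moved the number only modestly even though the whole ring was swapped. A smaller structural change is therefore expected to give a small step, perhaps none beyond the scatter, with the direction uncertain and a slight lean toward a higher number. Compound 3 is thus estimated at 0.25 nM, with a range of 0.08 nM to 0.8 nM, which corresponds to an expected step of a 1.8-fold higher number from compound 2 to compound 3 (0.25 log units; within the scatter).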

Compound 3, half-maximal inhibitory concentration: 0.1 nM
The estimate for compound 3 lay 2.5-fold (0.40 log units) above the measured number; the range from low to high includes it.
By their numbers in this assay, from the lowest: compounds 3 and 2 (each within the scatter of the next); then compound 1.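

At the double-bonded ring carbon, adding one oxygen atom to the ring nitrogen of the pyridin-4-yl group gives a 1.4-fold lower number from compound 2 to compound 3 (0.15 log units; within the scatter) in this assay, so the two compounds cannot be told apart and the added oxygen is tolerated at this position. The ring that carries this oxygen also stands clear of the 4-(hydroxymethyl)phenyl group, with a 3.9-fold lower number from compound 1 to compound 3 (0.59 log units; beyond the scatter), so both rings with a ring nitrogen now separate from compound 1 by more than the scatter. Nothing available here speaks to why the oxygen leaves the number within the scatter.

On these data alone, it remains open what a plain phenyl ring, a pyridin-3-yl ring or a 4-(aminomethyl)phenyl group would give on this carbon, so the three compounds cannot show whether the gain over compound 1 goes with the ring nitrogen or with the loss of the hydroxymethyl group. Also open, as far as these compounds go, is whether the oxygen on the ring nitrogen would fare the same if the rest of the shared core were changed, since all three compounds keep it intact.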